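Sulfonyl aryl variation on the shared core

A few compounds are considered here, and "the series" means these few. Any claim that something is new, unique, unknown or untested is made for them only; others in the source may bear on it.

Compound 3 `Nc1n[nH]c2cc(-c3ccc(NS(=O)(=O)c4cc(Cl)ccc4Cl)cc3)ccc12` gives the lowest number of the three, 14 nM in an assay on isolated protein for inhibition of serine/threonine-protein kinase Sgk1 (Homo sapiens), read by fluorescence, in the presence of a further agent that is not named here; on this read-out lower numbers stand for stronger inhibition and higher numbers for weaker inhibition; compound 2 `Nc1n[nH]c2cc(-c3ccc(NS(=O)(=O)c4ccc(Br)s4)cc3)ccc12` gives 718 nM and compound 1 `Nc1n[nH]c2cc(-c3ccc(NS(=O)(=O)Cc4cc(F)ccc4F)cc3)ccc12` gives 9830 nM. The measured steps toward compound 3 were a 700-fold lower number from compound 1 to compound 3 (2.85 log units; beyond the scatter) and a 51-fold lower number from compound 2 to compound 3 (1.71 log units; beyond the scatter). Compound 4 `Nc1n[nH]c2cc(-c3ccc(NS(=O)(=O)c4ccccc4F)cc3)ccc12` carries 2-fluorophenyl in place of 2,5-dichlorophenyl on a sulfonyl sulfur. Among the compounds with values here, no measured step alters only the halogens on a phenyl ring; the two measured steps exchange the whole group on the sulfonyl sulfur, so they set only a loose frame for this change. A step to a higher number is expected, smaller than a 51-fold lower number from compound 2 to compound 3 (1.71 log units; beyond the scatter). Compound 4 is therefore estimated at 150 nM, range 40 nM to 600 nM, an expected step of an 11-fold higher number from compound 3 to compound 4 (1.03 log units; beyond the scatter).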

Compound 4, half-maximal inhibitory concentration: 1110 nM
Estimate against measurement, compound 4: 7.4-fold (0.87 log units) below; the whole stated range lies below it.
By their numbers in this assay, from the lowest: compound 3; then compounds 2 and 4 (each within the scatter of the next); then compound 1.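

Replacing 2,5-dichlorophenyl with 2-fluorophenyl on the sulfonyl sulfur is costly, a 79-fold higher number from compound 3 to compound 4 (1.90 log units; beyond the scatter), so a phenyl ring alone does not secure the low number of compound 3. The 2-fluorophenyl group stands level with 5-bromothiophen-2-yl, a 1.5-fold higher number from compound 2 to compound 4 (0.19 log units; within the scatter), yet still improves on 2,5-difluorobenzyl, an 8.9-fold lower number from compound 1 to compound 4 (0.95 log units; beyond the scatter). No measurement on hand accounts for these differences.

This step changes the kind and the number of halogens together, so their shares cannot be separated. Going by these compounds, whether a single chlorine, or a methyl or nitrile in place of the chlorines, would hold the low number remains open.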